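Swapping isopropyl for methyl: an expected half-life

A few compounds are considered here, and "the series" means these few. Any claim that something is new, unique, unknown or untested is made for them only; others in the source may bear on it.

In an ADME assay (liver, Mus musculus) for metabolic stability, read by LC-MS, using microsomes, tested at 1 uM (on this read-out higher numbers stand for a longer-lived compound and lower numbers for a shorter-lived compound), compound 1 `CCN(CC)CCCCCN/C(C)=N\c1ccnc2cc(Cl)ccc12` gives > 1 h which is a limit of the assay and not a number. Compound 2 `CCN(CC)CCN/C(C)=N\c1ccnc2cc(Cl)ccc12` gives 0.3 h while compound 3 `CCN(CC)CCCCN/C(=N\c1ccnc2cc(Cl)ccc12)C(C)C` gives 0.7 h and so holds the higher of the two actual numbers. Compound 4 `CCN(CC)CCCCN/C(C)=N\c1ccnc2cc(Cl)ccc12` differs from compound 3 by methyl in place of isopropyl on a carbon with a double bond to nitrogen with methyl in place of isopropyl on a carbon with a double bond to nitrogen. For the measured compounds named here, the only measured step is an at least 3.3-fold lower number from compound 1 to compound 2 (0.52 log units; beyond the scatter) and it lies in the chain, not at that carbon, so it offers no direct size for this change. No step beyond the scatter is therefore expected in this assay and the estimated step is a 1.2-fold lower number from compound 3 to compound 4 (0.07 log units; within the scatter) in this case. Compound 4 is expected at 0.6 h with an estimated range from 0.3 h to 1.3 h for its half-life.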

Compound 4, half-life: > 1 h
Compound 4 was reported as a limit (the forecaster's own chance of this, stated with the estimate: 15%); middle value at least 1.6-fold (0.22 log units) away from the limit.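

At the carbon with a double bond to nitrogen, methyl in place of isopropyl gives an at least 1.4-fold higher number from compound 3 to compound 4 (0.15 log units; that floor lies within the scatter) in this assay and so shows no shortening of the half-life when isopropyl leaves. The chain gains a second reading, an at least 3.3-fold higher number from compound 2 to compound 4 (0.52 log units; beyond the scatter) and this agrees with the earlier chain step. Compound 4 stands at a limit of the assay, and its step to compound 1 cannot be read: the limit of > 1 h in this assay, at which 2 of the 4 values shown sit.

Going by these compounds, how far compound 3 and compound 4 truly differ remains open. So does what ethyl or phenyl would do at this carbon.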